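From methylsulfanyl to nitro on the shared core

A few compounds are considered here, and "the series" means these few. Any claim that something is new, unique, unknown or untested is made for them only; others in the source may bear on it.

In a functional assay on MCF7 cells (Homo sapiens) for antiproliferative activity, read by MTT assay, with a stated time of 48 h (a higher number here means a weaker inhibitor, a lower number a stronger inhibitor), compound 2 (`COc1ccc2c(/C=C/C(=O)c3cc(OC)c(OC)c(SC)c3)cn(C)c2c1`) gives 166 nM. That lies within the scatter of compound 3 (`COc1cc(C(=O)/C=C/c2cn(C)c3ccccc23)cc(SC)c1OC`) at 102 nM, while compound 1 (`COc1ccc2c(/C=C/C(=O)c3cc(OC)c(OC)c([N+](=O)[O-])c3)c[nH]c2c1`) stands clearly higher at 662 nM. Compound 4 (`COc1ccc2c(/C=C/C(=O)c3cc(OC)c(OC)c([N+](=O)[O-])c3)cn(C)c2c1`) departs from compound 2 by one change: nitro in place of methylsulfanyl on an aromatic carbon. Among the measured compounds shown here, the only measured step, a 1.6-fold lower number from compound 2 to compound 3 (0.21 log units; within the scatter), is a different change, hydrogen in place of methoxy on an aromatic carbon, and offers little guidance. Compound 1 also carries nitro but differs from compound 2 in more than this group, so compound 1 at 662 nM hints only loosely at a higher number in this assay. The expected step is a 2.0-fold higher number from compound 2 to compound 4 (0.30 log units; within the scatter). Compound 4 is estimated at 330 nM, within an expected range of 110 nM to 1000 nM.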

Compound 4, half-maximal inhibitory concentration: 1520 nM
Estimate against measurement, compound 4: 4.6-fold (0.66 log units) below; measured number outside the range, above it.
By their numbers in this assay, from the lowest: compounds 3 and 2 (each within the scatter of the next); then compound 1; then compound 4.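

In this assay, among the compounds shown here, putting nitro in place of methylsulfanyl on this aromatic carbon, ortho to a methoxy group, gives a large step, a 9.2-fold higher number from compound 2 to compound 4 (0.96 log units; beyond the scatter), which the earlier compounds did not reveal. With nitro in place, methyl in place of hydrogen on the aromatic nitrogen moves the number the same way, a 2.3-fold higher number from compound 1 to compound 4 (0.36 log units; beyond the scatter), so that change does not recover the loss. No measured evidence here bears on the reason for either step.

From the compounds shown here alone, whether an amine, a nitrile or a carboxylic acid at this position would stay near compound 2 or shift as far as nitro remains open. So does whether that nitrogen methyl would have the same effect with methylsulfanyl on the ring.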